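Removing the methanesulfonamido group from compound 3

A few compounds are considered here, and "the series" means these few. Any claim that something is new, unique, unknown or untested is made for them only; others in the source may bear on it.

Going by the values given here, in a functional assay on NCI-H460 cells (Homo sapiens) for cytotoxicity, read by MTT assay, with a stated time of 96 h (a higher number here means a weaker inhibitor, a lower number a stronger inhibitor), compound 3 (`COc1ncc(-c2cc(OC3CCOCC3)c3nc(N)nc(C)c3c2)cc1NS(C)(=O)=O`) gives 860 nM, the highest number of the three measured so far. Compound 1 (`COCCOc1cc(-c2cnc(OC)c(NS(=O)(=O)c3ccc(F)cc3F)c2)cc2c(C)nc(N)nc12`) gives 200 nM and compound 2 (`COc1ncc(-c2cc(OC3CCCCC3)c3nc(N)nc(C)c3c2)cc1NS(=O)(=O)c1ccc(F)cc1F`) gives 96 nM, and both lie beyond the scatter from compound 3.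

The next compound is compound 4 (`COc1ccc(-c2cc(OC3CCOCC3)c3nc(N)nc(C)c3c2)cn1`), which carries hydrogen in place of methanesulfonamido on an aromatic carbon.

Among the compounds with values here, the only measured step, a 2.1-fold lower number from compound 1 to compound 2 (0.32 log units; beyond the scatter), involves the group on an oxygen on an aromatic ring. It therefore sets only a rough scale and says nothing directly about this change. Within the data shown here, all three measured compounds carry a sulfonamide at the changed place, and no measured compound lacks one, so the data do not show what its loss does. The direction below is a judgement, and the range is kept wide for that reason.

A higher number in this assay is expected, with a shift somewhat larger than the modest step from compound 1 to compound 2. The expected step is a 2.9-fold higher number from compound 3 to compound 4 (0.46 log units; beyond the scatter). For compound 4 the estimated value is 2500 nM, with an expected range of 600 nM to 10000 nM.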

Compound 4, half-maximal inhibitory concentration: 980 nM
Estimate against measurement, compound 4: 2.6-fold (0.41 log units) above, and the stated range covers the measured number.
By their numbers in this assay, from the lowest: compound 2; then compound 1; then compounds 3 and 4 (each within the scatter of the next).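

Hydrogen in place of methanesulfonamido on this aromatic carbon gives a 1.1-fold higher number from compound 3 to compound 4 (0.06 log units; within the scatter) in this assay, so compound 4, the first compound shown with no sulfonamide at this place, reads the same as compound 3 within the scatter. With the rest of the structure held constant, the methanesulfonamido group therefore makes no difference that this read-out can separate, and hydrogen is enough at this place to give a number of this size. No measurement at hand bears on why the two compounds read alike.

The result covers only the methanesulfonamido group, so it remains open whether hydrogen would also leave the number unchanged in place of the fluorinated benzenesulfonamido group carried by compound 1 and compound 2, for which the compounds shown hold no matched pair. Also open, going by these compounds, is how an amine, a hydroxyl or a carboxylic acid on this aromatic carbon would compare with hydrogen and methanesulfonamido in this cell assay.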